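Compound 4: a naphthalene for a cyclobutane

A few compounds are considered here, and "the series" means these few. Any claim that something is new, unique, unknown or untested is made for them only; others in the source may bear on it.

Measured so far in a functional assay on A2780 cells (Homo sapiens) for antiproliferative activity, read by fluorescence, with a stated time of 72 h; on this read-out higher numbers stand for weaker inhibition and lower numbers for stronger inhibition:
compound 1 `CC(C)(C)C(=O)N1Cc2c(NC(=O)C3CCNCC3)n[nH]c2C1(C)C`: 650 nM
compound 2 `CN1CCC(C(=O)N2Cc3c(NC(=O)C4CCC4)n[nH]c3C2(C)C)CC1`: 140 nM
compound 3 `CC1(C)c2[nH]nc(NC(=O)c3ccc(F)cc3)c2CN1C(=O)C1CCN(C2CC2)CC1`: 380 nM

Compound 2, at 140 nM, has the lowest number of the three, which makes it the strongest inhibitor here. Its two neighbours both lie beyond the scatter from it: compound 3 gives 380 nM and compound 1 gives 650 nM.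

The next compound to be tested is compound 4 `CN1CCC(C(=O)N2Cc3c(NC(=O)c4ccc5ccccc5c4)n[nH]c3C2(C)C)CC1`, which differs from compound 2 in one place: naphthalen-2-yl in place of cyclobutyl on a carbonyl carbon. In short, naphthalen-2-yl stands in place of cyclobutyl on a carbonyl carbon.

Among the measured compounds shown here, no measured pair isolates a change of this kind, so the expectation rests on thin ground. For the measured compounds named here, compound 3 is the only measured compound with an aromatic ring on that carbonyl carbon, and it gives 380 nM in this assay, but it also differs from compound 2 elsewhere. Compound 1 has no aromatic ring there and still gives 650 nM, which goes against any simple reading.

A small move toward a higher number is therefore expected, probably not clearly beyond the scatter, and the estimated change is a 1.8-fold higher number from compound 2 to compound 4 (0.25 log units; within the scatter). For compound 4 the estimated value is 250 nM, with an expected range from 70 nM to 900 nM.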

Compound 4, half-maximal inhibitory concentration: 270 nM
The estimate for compound 4 lay 1.1-fold (0.03 log units) below the measured number; low and high end bracket the measured number.
By their numbers in this assay, from the lowest: compounds 2, 4, 3 and 1 (each within the scatter of the next, the first and the last beyond it).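

In this assay, among the compounds shown here, naphthalen-2-yl in place of cyclobutyl on a carbonyl carbon gives a 1.9-fold higher number from compound 2 to compound 4 (0.29 log units; within the scatter), the first step in which this position alone varies and the rest of the compound stays fixed. For this one pair, a group of 10 heavy atoms with two six-membered aromatic rings and a group of 4 heavy atoms with one four-membered non-aromatic ring are not told apart by this read-out, so the aromatic rings and the added carbon atoms carry no cost here that stands clear of the scatter. No evidence at hand bears on this result.

Compound 1 and compound 3 each differ from compound 4 in more than one place, so neither shows whether the same exchange would give a similar step with the other groups on the far amide carbonyl. Also open, from the compounds shown here alone, is how this carbonyl position would respond to a group bearing an amine or a carboxylic acid, such as a piperidin-4-yl ring or a pyridine ring, since only carbon-only rings are compared here.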